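The compounds below may be only part of what the source reports. "The series", "measured", "known", "first", "only" and "open" are said of these compounds alone.

Compound 1, `c1ccc(-c2cn3ccnc3c(-c3ccc4ncn(C5CCCCC5)c4c3)n2)cc1`, and compound 2, `Clc1ccc(-c2cn3ccnc3c(-c3ccc4ncn(C5CCCCC5)c4c3)n2)cc1`, share one core and differ only in the para substituent of the phenyl ring. In a functional assay on M14 cells (Homo sapiens) for inhibition, read by sulforhodamine B assay, with a stated time of 48 h, tested at 10 uM (on this read-out lower numbers stand for less inhibition and higher numbers for more inhibition at the one concentration tested (going by the name of the read-out)), compound 1 gives 38.2%, and compound 2 gives 10%, the lowest of the two numbers. The step of a number 28.2 percentage points lower from compound 1 to compound 2 (beyond the scatter) is modest but beyond the scatter. Compound 3, `Fc1ccccc1-c1cn2ccnc2c(-c2ccc3ncn(C4CCCCC4)c3c2)n1`, carries 2-fluorophenyl in place of 4-chlorophenyl on an aromatic carbon. Among the measured compounds shown here, no measured step covers a fluorine in that position, so the only guidance is the chloro step, and a number between the two measured ones is expected: a number 10 percentage points higher from compound 2 to compound 3 (within the scatter), giving compound 3 an estimated 20% within 0% to 45%.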

Compound 3, a percentage reported as inhibition, at one concentration (the size of the read-out at that concentration, not a potency): 2.92%
Beside the measured number, compound 3's estimate is 17.1 percentage points above it; measured number inside the range.
By their numbers in this assay, from the lowest: compounds 3 and 2 (each within the scatter of the next); then compound 1.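

In this assay, 2-fluorophenyl in place of 4-chlorophenyl gives a number 7.1 percentage points lower from compound 2 to compound 3 (within the scatter), so this change of halogen and its place on the phenyl ring cannot be told apart from no change. Fluoro in place of hydrogen gives a number 35.3 percentage points lower from compound 1 to compound 3 (beyond the scatter), so the drop seen with chloro is not peculiar to chlorine or to one place on the phenyl ring. Nothing given here bears on the reason for these numbers.

Still open, on these data alone, is whether a phenyl ring carrying an amine or a methoxy group would stay near compound 1. Also open, as far as these compounds go, is whether chlorine and fluorine would match on the same ring carbon.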